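The source may hold more compounds than are shown below. What is called first, only, known or untested is meant among the compounds shown, and "the series" means these compounds.

The two measured compounds:
compound 1, `COc1cc(C)cc(-c2c(-c3ccnc(-c4ccc(C(C)=O)cc4)c3)cnn2CC#N)c1`, 19%;
compound 2, `Cc1cc(O)cc(-c2nn(CC#N)cc2-c2ccnc(-c3ccc(Oc4ccccc4)cc3)c2)c1`, 60%.

In a functional assay on HOP-62 cells (Homo sapiens) for cytotoxicity, read by sulforhodamine B assay, with a stated time of 48 h, tested at 1 uM (on this read-out lower numbers stand for a stronger effect and higher numbers for a weaker effect at the one concentration tested), compound 1 gives 19%, the lowest of the two numbers and therefore the stronger effect of the pair; its nearest neighbour, compound 2, gives 60%, a gap well beyond the usual scatter. Compound 3, `COc1cc(C)cc(-c2c(-c3ccnc(-c4ccc(N(C)C)cc4)c3)cnn2CC#N)c1`, has not yet been tested in this assay. It differs from compound 1 in one place: dimethylamino in place of acetyl on an aromatic carbon. Among the compounds with values here, no measured pair shows this same change, so the size and direction of the step rest on no measured step at all. With compound 1 already at the stronger end of what has been seen, the author expects a moderate step toward a weaker effect, a number 16 percentage points higher from compound 1 to compound 3 (beyond the scatter), while allowing that a step within the scatter would not be surprising. For compound 3 the estimate is 35%, with a range from 10% to 70%.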

Compound 3, a percentage reported as activity, at one concentration (the size of the read-out at that concentration, not a potency): 31%
Compound 3: middle estimate off by 4 percentage points, on the high side; the measured number falls inside the stated range.
By their numbers in this assay, from the lowest: compound 1; then compound 3; then compound 2.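

In this assay, within the data shown here, putting dimethylamino in place of acetyl on an aromatic carbon, para to a large group, gives a number 12 percentage points higher from compound 1 to compound 3 (beyond the scatter), the first step at this position that can be read. The two groups have the same count of heavy atoms, and each has one hydrogen-bond acceptor and no donor, so these counts do not separate them even though the number moves by a modest step beyond the scatter. No measured evidence accounts for the size or direction of this step.

This single step does not show how other groups at this place, such as a primary amine, a carboxylic acid or a longer chain, would compare with acetyl or dimethylamino. Compound 2 differs from compound 1 and compound 3 in more than one place, so it adds nothing on this position.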